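From Trifluoromethyl to Fluoro: What Compound 4 May Show

This account rests on a few compounds, and the source may have more. Where it says the series, first, only, none or still open, it means among the compounds named here.

Values in a functional assay on L6 cells (Rattus norvegicus) for cytotoxicity; a lower number here means a stronger inhibitor, a higher number a weaker inhibitor:
- compound 1 `N=C(NO)c1ccc(-c2ccc(-c3ccc(/C(N)=N/O)cc3)cc2)o1`: 106000 nM
- compound 2 `N=C(NO)c1ccc(-c2ccc(-c3ccc(/C(N)=N\O)cc3)cc2)cc1`: > 211000 nM (a limit, not a number)
- compound 3 `N=C(NO)c1ccc(-c2ccc(-c3ccc(/C(N)=N\O)cc3)cc2C(F)(F)F)cc1`: 13300000 nM

Only two of these are true numbers, and compound 3 holds the higher. Its gap to compound 1 lies beyond the scatter, so compound 3 is the weaker inhibitor of that pair in this assay. Compound 2 reports only a limit: the limit of > 211000 nM in this assay, at which 1 of the 3 values shown sits.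

Compound 4 `N=C(NO)c1ccc(-c2ccc(-c3ccc(/C(N)=N\O)cc3)cc2F)cc1` changes one group of compound 3: fluoro in place of trifluoromethyl on an aromatic carbon. This puts fluoro in place of trifluoromethyl on an aromatic carbon, ortho to a large group and meta to a large group. Within the data shown here, the only measured step at this place is a step that the limit leaves unreadable from compound 2 to compound 3, so no measured size can be carried over.

The direction can be judged only loosely. Compound 3 at 13300000 nM stands at the top of the numbers, and compound 1 at 106000 nM lies far lower, so a move down is more likely than a move up. The expected change is a 44-fold lower number from compound 3 to compound 4 (1.65 log units; beyond the scatter), though with wide uncertainty. For compound 4 the estimated value is 300000 nM, with an expected range from 60000 nM to 5000000 nM.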

Compound 4, half-maximal inhibitory concentration: 29100 nM
Compound 4: middle estimate off by 10-fold (1.01 log units), on the high side; measured number below the stated range.
By their numbers in this assay, from the lowest: compound 4; then compound 1; then compound 3.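

In this assay, among these compounds, the group on this aromatic carbon, ortho to a large group and meta to a large group, clearly matters: fluoro in place of trifluoromethyl gives a 460-fold lower number from compound 3 to compound 4 (2.66 log units; beyond the scatter), a size that the earlier compounds could not provide. Fluoro in place of hydrogen at the same place gives an at least 7.2-fold lower number from compound 2 to compound 4 (0.86 log units; beyond the scatter), which sets only a minimum size, while the step from compound 2 to compound 3 cannot be read. Compound 2 therefore remains the weak point of this comparison, as its value is a limit and not a number: the limit of > 211000 nM in this assay, at which 1 of the 4 values shown sits.

With only hydrogen, fluoro and trifluoromethyl shown at this place, it remains open how the number would respond to other groups there, such as chloro, methyl, an amine or a carboxylic acid. Going by these compounds, it is also open whether adding fluoro to the core of compound 1 would bring a similar step, or whether this effect belongs only to the core shared by compound 2, compound 3 and compound 4.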